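Indole diketo acid series: notes toward compound 4

The source may hold more compounds than are shown below. What is called first, only, known or untested is meant among the compounds shown, and "the series" means these compounds.

Measured compounds:
- compound 1 `CCOC(=O)C(=O)CC(=O)/C=C/c1cn(CCC(C)C)c2ccccc12`: "not determined" (no result reported)
- compound 2 `CCOC(=O)C(=O)CC(=O)/C=C/c1cn(-c2ccc(O)cc2)c2ccccc12`: "not determined" (no result reported)
- compound 3 `CC(C)CCn1cc(/C=C/C(=O)CC(=O)C(=O)O)c2ccccc21`: 20000 nM

In a functional assay on MOLT-4 cells (Homo sapiens) for inhibition, read by MTT assay, with a stated time of 48 h (a lower number here means a stronger inhibitor, a higher number a weaker inhibitor), compound 3 gives 20000 nM. In this assay, for the measured compounds named here, compound 1 gives "not determined" (no result reported) and compound 2 gives "not determined" (no result reported), so compound 3 stands as the only measured point and there is no step between measured compounds against which a change can be weighed.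

Compound 4 `N#Cc1ccc(Cn2cc(/C=C/C(=O)CC(=O)C(=O)O)c3ccccc32)cc1` differs from compound 3 as follows: 4-cyanophenyl in place of isobutyl on a saturated chain carbon bound to an aromatic nitrogen. With nothing in the data to show how this exchange plays out, the step of a 1.3-fold lower number from compound 3 to compound 4 (0.12 log units; within the scatter) is expected to stay close to the usual scatter, at most a modest gain. Compound 4 is therefore estimated at 15000 nM, with a range from 4000 nM to 60000 nM.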

Compound 4, half-maximal inhibitory concentration: > 40000 nM
Compound 4 ended at the assay's limit; the forecaster's own chance of this, stated with the estimate: 20%; at least 2.6-fold (0.42 log units) between middle value and limit.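

In this assay, 4-cyanophenyl in place of isobutyl on a saturated chain carbon bound to an aromatic nitrogen gives an at least 2.0-fold higher number from compound 3 to compound 4 (0.30 log units; that floor lies within the scatter). Compound 4 carries a limit of the assay, not a number: the limit of > 40000 nM in this assay, at which 1 of the 4 values shown sits.

This first readable step at this position shows no lower number with the exchange, though its floor does not separate compound 4 from compound 3. As far as these compounds go, how far the true step lies past that floor stays open. So does the outcome at this position with a plain benzyl lacking the nitrile, an amine on the chain, or a longer alkyl chain.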